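The source may report more compounds than this note shows. Statements on the series, on what has been measured and on what is new or still open speak of the compounds shown alone.

The shared core carries a para-alkyl group whose length varies. Compound 1 `CCc1ccc(C(=O)CC(SCC(=O)O)C(=O)O)cc1` gives 4790 nM in a functional assay on HeLa cells (Homo sapiens); a higher number here means a weaker inhibitor, a lower number a stronger inhibitor; compound 2 `CCCCc1ccc(C(=O)CC(SCC(=O)O)C(=O)O)cc1` gives 1910 nM; compound 3 `CC(C)(C)c1ccc(C(=O)CC(SCC(=O)O)C(=O)O)cc1` gives 1390 nM. On these numbers compound 2 stands second highest, with a 1.4-fold lower number from compound 2 to compound 3 (0.14 log units; within the scatter) and a 2.5-fold lower number from compound 1 to compound 2 (0.40 log units; beyond the scatter). Compound 4 `CCCCCCCCCCCCc1ccc(C(=O)CC(SCC(=O)O)C(=O)O)cc1` extends the chain further: octyl in place of hydrogen on a saturated chain carbon, four bonds along the chain from an aromatic carbon. Going by the values given here, the one step that bears on lengthening, a 2.5-fold lower number from compound 1 to compound 2 (0.40 log units; beyond the scatter), was modest; a 3.4-fold lower number from compound 1 to compound 3 (0.54 log units; beyond the scatter) points the same way. A further, modest lowering is therefore expected, though the chain grows by far more than before, so the range is wide. Compound 4 is estimated at 1000 nM (from 300 nM to 4000 nM), meaning an expected 1.9-fold lower number from compound 2 to compound 4 (0.28 log units; within the scatter).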

Compound 4, half-maximal inhibitory concentration: 1710 nM
For compound 4 the middle estimate is 1.7-fold (0.23 log units) below the measured one; low and high end bracket the measured number.
By their numbers in this assay, from the lowest: compounds 3, 4 and 2 (each within the scatter of the next); then compound 1.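

Octyl added to the chain gives a 1.1-fold lower number from compound 2 to compound 4 (0.05 log units; within the scatter), so in this assay a chain this much longer cannot be told apart from the butyl chain of compound 2. Measured against the shorter chain of compound 1, the lowering persists, with a 2.8-fold lower number from compound 1 to compound 4 (0.45 log units; beyond the scatter), so the added length neither extends that gain nor loses it. Nothing available explains this levelling off. As far as these compounds go, whether a hexyl chain fits the same picture stays open, as does the effect of an amine or a carboxylic acid at the end of the long chain.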